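Swapping One Halogen for Another on the Sulfonyl Ring

This account rests on a few compounds, and the source may have more. Where it says the series, first, only, none or still open, it means among the compounds named here.

Three measured compounds share one core and differ only in small substituents. In a functional assay on B16-F10 cells (Mus musculus) for antiproliferative activity, read by ELISA and MTT assay, with a stated time of 48 h (a higher number here means a weaker inhibitor, a lower number a stronger inhibitor), compound 1 `O=C(/C=C/c1ccccc1)NS(=O)(=O)c1ccc(Cl)cc1` gives 2.2 ug/mL. Compound 2 `O=C(/C=C/c1ccc(F)cc1)NS(=O)(=O)c1ccc(Cl)cc1` gives 2.6 ug/mL; it carries fluoro where compound 1 carries hydrogen, and the step of a 1.2-fold higher number from compound 1 to compound 2 (0.07 log units; within the scatter) lies within the scatter. Compound 3 `CN(C)c1ccc(/C=C/C(=O)NS(=O)(=O)c2ccc(F)cc2)cc1` gives 2.3 ug/mL; its number sits nearest to that of compound 1 and furthest from that of compound 2, yet both gaps are within the scatter, so none of the three can be ranked against the others.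

Compound 4 `CN(C)c1ccc(/C=C/C(=O)NS(=O)(=O)c2ccc(Cl)cc2)cc1` has not been measured. It differs from compound 3 by chloro in place of fluoro on an aromatic carbon. Going by the values given here, no measured step covers this exact change. Among the compounds with values here, what the data offer is that compounds 1 and 2, both carrying chloro on that ring, give numbers indistinguishable from compound 3, which carries fluoro there, and that the one measured step, on the other ring, is itself within the scatter. The expected step is therefore no change at the digits printed from compound 3 to compound 4 (within the scatter), nothing beyond the scatter. Compound 4 is estimated at 2.3 ug/mL, within a range from 1.3 ug/mL to 4.2 ug/mL.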

Compound 4, half-maximal inhibitory concentration: 2.8 ug/mL
Beside the measured number, compound 4's estimate is 1.2-fold (0.09 log units) below it; low and high end bracket the measured number.
By their numbers in this assay, from the lowest: compounds 1, 3, 2 and 4 (each within the scatter of the next).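

In this assay the swap of chloro for fluoro on this aromatic carbon now has a direct reading, a 1.2-fold higher number from compound 3 to compound 4 (0.09 log units; within the scatter), so the two halogens cannot be told apart here. Dimethylamino on the other ring gives a 1.1-fold higher number from compound 2 to compound 4 (0.03 log units; within the scatter) when set against fluoro and a 1.3-fold higher number from compound 1 to compound 4 (0.10 log units; within the scatter) when set against hydrogen, so all three groups on that ring also fall together. No measurement on hand gives a reason why these numbers stay so close.

As far as these compounds go, it remains open whether the halogen swap reads the same when hydrogen or fluoro replaces the dimethylamino group on the other ring. Also open, from the compounds shown here alone, is whether a larger change on the halogen-bearing ring, such as a bromo, a methoxy or a carboxylic acid, would move the number beyond the scatter.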